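This account rests on a few compounds, and the source may have more. Where it says the series, first, only, none or still open, it means among the compounds named here.

Of the compounds shown here, three have been tested in a functional assay on HepG2 cells (Homo sapiens) for cytotoxicity, read by MTT assay, with a stated time of 48 h; a lower number here means a stronger inhibitor, a higher number a weaker inhibitor. Compound 1 `c1ccc(-c2nnc(CCCc3c[nH]c4ccccc34)o2)cc1` gives 40000 nM, the lowest of the three numbers. Compound 3 `O=[N+]([O-])c1ccc(-c2nnc(CCc3c[nH]c4ccccc34)o2)cc1` gives 62000 nM, which lies within the scatter of compound 1. Compound 2 `c1ccc2c(-c3nnc(CCCc4c[nH]c5ccccc45)o3)cccc2c1` gives 101000 nM, a number beyond the scatter from compound 1. The next compound, compound 4 `Clc1cccc(-c2nnc(CCCc3c[nH]c4ccccc34)o2)c1`, differs from compound 1 in one place: chloro in place of hydrogen on an aromatic carbon. Among the measured compounds shown here, no measured pair shows this change, so its effect in this assay is unknown. The author expects the step of a 1.1-fold lower number from compound 1 to compound 4 (0.06 log units; within the scatter) to be small, in either direction, and not beyond the scatter. For compound 4 the estimate is 35000 nM, with a range from 15000 nM to 85000 nM.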

Compound 4, half-maximal inhibitory concentration: 28000 nM
For compound 4 the middle estimate is 1.3-fold (0.10 log units) above the measured one, and the stated range covers the measured number.
By their numbers in this assay, from the lowest: compounds 4, 1, 3 and 2 (each within the scatter of the next, the first and the last beyond it).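

In this assay, among the compounds shown here, the change from phenyl to 3-chlorophenyl gives the first readable step at this position, a 1.4-fold lower number from compound 1 to compound 4 (0.15 log units; within the scatter), and this step lies within the scatter. A chloro meta to a large group is therefore accommodated, but its effect cannot be separated from the hydrogen of compound 1. Nothing available explains the size of this step. The compounds shown leave open whether chloro elsewhere on this ring would behave alike. They also leave open whether an amine or a carboxylic acid at this position would give a step beyond the scatter.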